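Dihydroxyphenyl isomer swap on the hydrazone-bearing carbon

A few compounds are considered here, and "the series" means these few. Any claim that something is new, unique, unknown or untested is made for them only; others in the source may bear on it.

Notes on the series. Compound 1 `CN(C)CCn1cnnc1-c1cc(Oc2ccc(NC(=O)N/N=C/c3ccc(Cl)cc3Cl)cc2F)ccn1` carries a 2,4-dichlorophenyl on the carbon with a double bond to nitrogen; in a functional assay on A549 cells (Homo sapiens) for cytotoxicity, read by MTT assay, with a stated time of 72 h (on this read-out lower numbers stand for stronger inhibition and higher numbers for weaker inhibition), compound 1 gives 810 nM. Compound 2 `COc1ccc(/C=N/NC(=O)Nc2ccc(Oc3ccnc(-c4nncn4CCN(C)C)c3)c(F)c2)c(OC)c1OC` gives 6680 nM, which is a step of an 8.2-fold higher number from compound 1 to compound 2 (0.92 log units; beyond the scatter). Compound 3 `CN(C)CCn1cnnc1-c1cc(Oc2ccc(NC(=O)N/N=C/c3ccc(O)c(O)c3)cc2F)ccn1` reaches only the assay limit, > 100000 nM; this value is a limit and not a number. The step of an at least 120-fold higher number from compound 1 to compound 3 (2.09 log units; beyond the scatter) and the step of an at least 14-fold higher number from compound 2 to compound 3 (1.17 log units; beyond the scatter) both place compound 3 at the weak end of the three; on the numbers shown it is the weakest, standing at the limit of > 100000 nM in this assay, at which 1 of the 3 values shown sits.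

Compound 4 `CN(C)CCn1cnnc1-c1cc(Oc2ccc(NC(=O)N/N=C/c3ccc(O)cc3O)cc2F)ccn1` differs from compound 3 by 2,4-dihydroxyphenyl in place of 3,4-dihydroxyphenyl on a carbon with a double bond to nitrogen. Within the data shown here, no measured pair rearranges the same atoms on this phenyl in this way, so none of the steps bears directly on the move; the steps that touch compound 3 are the two above, each large and each running toward the limit. The expectation is therefore that compound 4 stays near the weak end, with no more than a modest change, an at least 1.6-fold lower number from compound 3 to compound 4 (0.22 log units; that floor lies within the scatter). Compound 4 is estimated at 60000 nM, in the range 15000 nM to 200000 nM, with a real chance that again only a limit is reported.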

Compound 4, half-maximal inhibitory concentration: 12700 nM
Beside the measured number, compound 4's estimate is 4.7-fold (0.67 log units) above it; the measured number lies below the stated range.
By their numbers in this assay, from the lowest: compound 1; then compounds 2 and 4 (each within the scatter of the next). At a limit, above all of these: compound 3.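

Moving one hydroxyl on the phenyl, with the heavy-atom count unchanged, gives an at least 7.8-fold lower number from compound 3 to compound 4 (0.89 log units; beyond the scatter) in this assay, so this position responds to the arrangement of the hydroxyl groups and not only to their presence. The value for compound 3 is a limit and not a number, so that step gives only a floor: the limit of > 100000 nM in this assay, at which 1 of the 4 values shown sits. With 2,4-dihydroxyphenyl in place, the comparison with the 2,3,4-trimethoxyphenyl of compound 2 shows a 1.9-fold higher number from compound 2 to compound 4 (0.28 log units; within the scatter), while the comparison with the 2,4-dichlorophenyl of compound 1 shows a 16-fold higher number from compound 1 to compound 4 (1.20 log units; beyond the scatter), so the same arrangement carrying chlorine rather than hydroxyl remains clearly ahead.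

The compounds shown leave open which of the two hydroxyl groups accounts for the step, a question that 2-hydroxyphenyl and 4-hydroxyphenyl would address. Going by these compounds, it is also open whether the arrangement of compound 4 is favoured in general, or only for hydroxyl, which 3,4-dichlorophenyl and 2,4-dimethoxyphenyl would test on the same carbon with a double bond to nitrogen.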